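Halogen Swap on the Triazole Aryl Group

The source may hold more compounds than are shown below. What is called first, only, known or untested is meant among the compounds shown, and "the series" means these compounds.

Going by the values given here, compound 1 `COc1ccccc1-n1nncc1CN1C(=O)C2(C(C#N)=C(N)Oc3c(N)cc4nc5ccccc5nc4c32)c2ccccc21` supplies the only numerical value here: in a functional assay on MCF7 cells (Homo sapiens) for antiproliferative activity, read by MTT assay, with a stated time of 48 h (on this read-out lower numbers stand for stronger inhibition and higher numbers for weaker inhibition), compound 1 gives 28900 nM. Compound 2 `Cc1ccc(-n2nncc2CN2C(=O)C3(C(C#N)=C(N)Oc4c(N)cc5nc6ccccc6nc5c43)c3ccccc32)cc1C` carries a 3,4-dimethylphenyl in place of the 2-methoxyphenyl on the aromatic nitrogen, and in this assay compound 2 reaches only the limit of the assay, > 50000 nM. Compound 3 `N#CC1=C(N)Oc2c(N)cc3nc4ccccc4nc3c2C12C(=O)N(Cc1cnnn1-c1c(F)cccc1F)c1ccccc12` bears a 2,6-difluorophenyl on the aromatic nitrogen; in this assay compound 3 likewise stops at the assay limit, > 50000 nM. Compound 3 thus stands at the limit of > 50000 nM in this assay, at which 2 of the 3 values shown sit, and the step of an at least 1.7-fold higher number from compound 1 to compound 3 (0.23 log units; that floor lies within the scatter) is only a floor. The step that the two limits leave unreadable from compound 2 to compound 3 tells nothing at all. Compound 4 `N#CC1=C(N)Oc2c(N)cc3nc4ccccc4nc3c2C12C(=O)N(Cc1cnnn1-c1ccc(F)c(Cl)c1)c1ccccc12` differs from compound 3 as follows: 3-chloro-4-fluorophenyl in place of 2,6-difluorophenyl on an aromatic nitrogen. Among the compounds with values here, no measured step involves a 3-chloro-4-fluorophenyl, and both steps ending at compound 3 are cut off by the limit, so the expected step of an at least 1.1-fold lower number from compound 3 to compound 4 (0.04 log units; that floor lies within the scatter) in this assay is small and of uncertain direction. Compound 4 is therefore estimated at 45000 nM in this assay, with a range from 15000 nM to 150000 nM.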

Compound 4, half-maximal inhibitory concentration: 17800 nM
The estimate for compound 4 lay 2.5-fold (0.40 log units) above the measured number; the range from low to high includes it.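

In this assay, the change at this aromatic nitrogen from 2,6-difluorophenyl to 3-chloro-4-fluorophenyl moves the result off the limit of the assay, giving an at least 2.8-fold lower number from compound 3 to compound 4 (0.44 log units; beyond the scatter). Replacing 3,4-dimethylphenyl with the same group gives an at least 2.8-fold lower number from compound 2 to compound 4 (0.44 log units; beyond the scatter), and both of these steps are only floors, set by a limit of the assay: the limit of > 50000 nM in this assay, at which 2 of the 4 values shown sit. Replacing 2-methoxyphenyl with 3-chloro-4-fluorophenyl gives a 1.6-fold lower number from compound 1 to compound 4 (0.21 log units; within the scatter), so the two aryl groups that reach a number cannot be told apart here, while the position still separates them from the two that stop at the limit.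

The compounds shown leave open whether the chlorine or the fluorine carries the step, which a phenyl with chlorine alone or fluorine alone could separate. They also leave open how an aryl ring bearing an amine or a carboxylic acid would read at this position.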